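Amide aryl variation on the shared core: ring position

This account rests on a few compounds, and the source may have more. Where it says the series, first, only, none or still open, it means among the compounds named here.

Measured in an assay on HEK293 cells for antagonist activity at P2X purinoceptor 7 (Homo sapiens), read by fluorescence, with a stated time of 2 h; on this read-out lower numbers stand for stronger inhibition and higher numbers for weaker inhibition:
Compound 1 `O=C(c1ccc(Cl)c(C(F)(F)F)c1)N1CCC(n2cncc2-c2ccc(OS(=O)(=O)c3cccc4cnccc34)cc2)CC1` gives 45 nM.
Compound 2 `CS(=O)(=O)c1ccc(C(=O)N2CCC(n3cncc3-c3ccc(OS(=O)(=O)c4cccc5cnccc45)cc3)CC2)cc1` gives 25 nM.
Compound 3 `CN(C)c1ccc(C(=O)N2CCC(n3cncc3-c3ccc(OS(=O)(=O)c4cccc5cnccc45)cc3)CC2)cc1` gives 0.11 nM.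

Compound 3 holds the lowest number of the three, and both of its steps are large and beyond the scatter: a 410-fold lower number from compound 1 to compound 3 (2.61 log units; beyond the scatter) and a 230-fold lower number from compound 2 to compound 3 (2.36 log units; beyond the scatter). The remaining pair moves little, as a 1.8-fold lower number from compound 1 to compound 2 (0.26 log units; within the scatter) stays within the scatter. Among the compounds with values here, the amide aryl group is thus the only part varied here, and the dimethylamino-bearing ring is the one that separates compound 3 from the rest.

Compound 4 `CN(C)c1cccc(C(=O)N2CCC(n3cncc3-c3ccc(OS(=O)(=O)c4cccc5cnccc45)cc3)CC2)c1` carries the change (3-(dimethylamino)phenyl in place of 4-(dimethylamino)phenyl on a carbonyl carbon). Within the data shown here, no measured pair shifts a group from one position to another on this ring, so neither of the large steps speaks directly to this move; they show only that the dimethylamino group in its measured place stands far apart from the other two substituents. The expectation for compound 4 therefore rests on compound 3 alone and on the width of that gap: some of it is expected to close when the group is relocated, but the number is still expected to sit well under those of compound 1 and compound 2. For compound 4 the estimate is 2 nM, within 0.2 nM to 20 nM. The expected step is an 18-fold higher number from compound 3 to compound 4 (1.26 log units; beyond the scatter).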

Compound 4, half-maximal inhibitory concentration: 155 nM
Estimate against measurement, compound 4: 78-fold (1.89 log units) below, and the stated range ends below it.
By their numbers in this assay, from the lowest: compound 3; then compounds 2 and 1 (each within the scatter of the next); then compound 4.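

Moving the dimethylamino group while keeping the same atoms gives the largest step seen in this series (a 1400-fold higher number from compound 3 to compound 4 (3.15 log units; beyond the scatter)). The low number of compound 3 therefore belongs to 4-(dimethylamino)phenyl on the carbonyl carbon, not to the presence of a dimethylamino group on the ring as such. The 3-(dimethylamino)phenyl group also fails to match the two amides without a dimethylamino group (a 6.2-fold higher number from compound 2 to compound 4 (0.79 log units; beyond the scatter); a 3.4-fold higher number from compound 1 to compound 4 (0.54 log units; beyond the scatter)), and both steps are modest but beyond the scatter, leaving compound 4 with the highest number of the four. The two dimethylaminophenyl groups have the same counts of heavy atoms, hydrogen-bond donors and acceptors and the same net charge, and no data at hand explain the effect of the shift.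

As far as these compounds go, it remains open whether a methylamino group, a primary amine or a methoxy group in place of the dimethylamino group of compound 3 would keep a number near that of compound 3. From the compounds shown here alone, it is also open whether a methylsulfonyl group, shifted on the ring as the dimethylamino group is here, would show a step of similar size.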